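A few compounds are considered here, and "the series" means these few. Any claim that something is new, unique, unknown or untested is made for them only; others in the source may bear on it.

Working notes on the series. Within the data shown here, the shared core is that of compound 1 `OC[C@H]1O[C@@H](n2cnc3c(NCc4cccc(F)c4)ncnc32)[C@H](O)[C@@H]1O`, which in a functional assay on K562 cells (Homo sapiens) for antiproliferative activity, with a stated time of 72 h (a higher number here means a weaker inhibitor, a lower number a stronger inhibitor), gives 7600 nM, the lowest of the three numbers measured so far. Compound 3 `OC[C@H]1O[C@@H](n2cnc3c(NCc4cccc(Br)c4)ncnc32)[C@H](O)[C@@H]1O` gives 19700 nM in this assay, and compound 2 `OC[C@H]1O[C@@H](n2cnc3c(NCc4ccccc4Cl)ncnc32)[C@H](O)[C@@H]1O` gives 64000 nM. The step of a 2.6-fold higher number from compound 1 to compound 3 (0.41 log units; beyond the scatter) and the larger step of an 8.4-fold higher number from compound 1 to compound 2 (0.93 log units; beyond the scatter) both run in the same direction; the step of a 3.2-fold lower number from compound 2 to compound 3 (0.51 log units; beyond the scatter) sets the two halogenated variants apart from each other.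

Compound 4 `OC[C@H]1O[C@@H](n2cnc3c(NCc4ccc(Cl)c(Cl)c4)ncnc32)[C@H](O)[C@@H]1O` is not yet measured. It differs from compound 1 by 3,4-dichlorophenyl in place of 3-fluorophenyl on a saturated chain carbon bound to a nitrogen on an aromatic ring. The nearest comparison is compound 3, where a 2.6-fold higher number from compound 1 to compound 3 (0.41 log units; beyond the scatter) shows that a heavier halogen in the same place on the ring raises the number moderately; compound 2 shows, through an 8.4-fold higher number from compound 1 to compound 2 (0.93 log units; beyond the scatter), that moving the halogen costs more. Among the measured compounds shown here, no measured pair carries two halogens on the ring, so the second chloro is uncharted. A step of the order of a 2.4-fold higher number from compound 1 to compound 4 (0.37 log units; beyond the scatter) is therefore expected, towards a higher number. Compound 4 is estimated at 18000 nM, with a range from 6000 nM to 55000 nM.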

Compound 4, half-maximal inhibitory concentration: 10800 nM
Beside the measured number, compound 4's estimate is 1.7-fold (0.22 log units) above it; the measured number falls inside the stated range.
By their numbers in this assay, from the lowest: compounds 1, 4 and 3 (each within the scatter of the next, the first and the last beyond it); then compound 2.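

In this assay, the 3,4-dichlorophenyl group carries two halogens on the ring, yet the step stays within the scatter on both sides: a 1.4-fold higher number from compound 1 to compound 4 (0.15 log units; within the scatter) and a 1.8-fold lower number from compound 3 to compound 4 (0.26 log units; within the scatter). A second halogen on the ring therefore does not by itself move the number beyond the scatter of either compound, although those two compounds remain beyond the scatter of each other, while the separation from the 2-chlorophenyl variant is clear, at a 5.9-fold lower number from compound 2 to compound 4 (0.77 log units; beyond the scatter). No supporting measurement is available to explain these numbers.

The compounds shown leave open whether a 3-chlorophenyl group would read closer to compound 1 or to compound 2 in this assay. As far as these compounds go, how a methoxy group, an amine or a longer chain on the ring would compare also remains open.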